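Removing a Nitro Group from the Ring-Nitrogen Substituent

The source may report more compounds than this note shows. Statements on the series, on what has been measured and on what is new or still open speak of the compounds shown alone.

Compound 1, `N=C1S/C(=C\c2ccc(OCc3ccccc3)cc2)C(=O)N1c1ccc(F)cc1`, in an ADME assay on RAW264.7 cells (Mus musculus) for cytotoxicity, read by MTT assay, with a stated time of 48 h, tested at 50 uM; on this read-out higher numbers stand for more inhibition at the one concentration tested (going by the name of the read-out) and lower numbers for less inhibition: 10.5%
Compound 2, `N=C1S/C(=C\c2ccc(OCc3ccccc3)cc2)C(=O)N1c1ccccc1[N+](=O)[O-]`, in this assay: 24.4%
Compound 3, `N=C1S/C(=C\c2ccc(OCc3ccccc3)cc2)C(=O)N1c1ncccn1`, in this assay: 26.6%

All three share one core and differ only in the group on the amide-type nitrogen in the ring. Compound 2 stands second highest of the three numbers. Its nearest neighbour is compound 3, and that step, a number 2.2 percentage points higher from compound 2 to compound 3 (within the scatter), lies within the scatter, so the two cannot be ranked. Its furthest neighbour is compound 1, and the step of a number 13.9 percentage points higher from compound 1 to compound 2 (beyond the scatter) is a modest rise beyond the scatter.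

Compound 4, `N=C1S/C(=C\c2ccc(OCc3ccccc3)cc2)C(=O)N1c1ccccc1`, differs from compound 2 in one place: hydrogen in place of nitro on an aromatic carbon

Among the measured compounds shown here, no measured step removes a nitro group alone. The step that bears most on it is a number 13.9 percentage points higher from compound 1 to compound 2 (beyond the scatter), since compound 1 also carries a phenyl-type group with only a small substituent on that nitrogen. Compound 4 is therefore expected to fall between compound 1 and compound 2, a modest drop of a number 9.4 percentage points lower from compound 2 to compound 4 (within the scatter). For compound 4 the estimated value in this assay is 15%, with a range from 5% to 28%.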

Compound 4, a percentage reported as inhibition, at one concentration (the size of the read-out at that concentration, not a potency): 37.9%
For compound 4 the middle estimate is 22.9 percentage points below the measured one, and the stated range ends below it.
By their numbers in this assay, from the lowest: compound 1; then compounds 2 and 3 (each within the scatter of the next); then compound 4.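

In this assay, the unsubstituted phenyl ring of compound 4 gives the highest number of the four, so a bare ring on this nitrogen is not a low starting point. Replacing the nitro with hydrogen gives a number 13.5 percentage points higher from compound 2 to compound 4 (beyond the scatter) and replacing the fluoro with hydrogen gives a number 27.4 percentage points higher from compound 1 to compound 4 (beyond the scatter) on the same ring, while swapping the pyrimidin-2-yl ring for phenyl gives a number 11.3 percentage points higher from compound 3 to compound 4 (beyond the scatter) at this nitrogen. The earlier rise from the 4-fluorophenyl to the 2-nitrophenyl compound therefore compares two compounds that both sit under the bare ring, and is no gain over it.

Nothing measured here explains these differences. Going by these compounds, whether an amine or a methoxy group in the place of the nitro would also sit under compound 4 remains open.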